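Amide aryl swap on the pyridinylmethyl core

A few compounds are considered here, and "the series" means these few. Any claim that something is new, unique, unknown or untested is made for them only; others in the source may bear on it.

Compound 1 `O=C(CN1CCN(c2nnc(Cc3ccccc3)c3ccccc23)CC1)Nc1ccc(F)c(F)c1` in a functional assay on HT-29 cells (Homo sapiens) for cytotoxicity, read by MTT assay, with a stated time of 72 h (on this read-out higher numbers stand for weaker inhibition and lower numbers for stronger inhibition), gives 9510 nM. Compound 2 `Cc1cccc(Cl)c1NC(=O)CN1CCN(c2nnc(Cc3ccccc3)c3ccccc23)CC1` gives 53600 nM; the change 2-chloro-6-methylphenyl in place of 3,4-difluorophenyl on an amide-type nitrogen made a 5.6-fold higher number from compound 1 to compound 2 (0.75 log units; beyond the scatter). Compound 3 `O=C(CN1CCN(c2nnc(Cc3ccncc3)c3ccccc23)CC1)Nc1ccc(F)c(F)c1` gives 2320 nM; its core differs from that of compound 1 by pyridin-4-yl in place of phenyl on a saturated chain carbon bound to an aromatic carbon, giving a 4.1-fold lower number from compound 1 to compound 3 (0.61 log units; beyond the scatter). Compound 4 `Cc1cccc(Cl)c1NC(=O)CN1CCN(c2nnc(Cc3ccncc3)c3ccccc23)CC1` is unmeasured; it differs from compound 3 by 2-chloro-6-methylphenyl in place of 3,4-difluorophenyl on an amide-type nitrogen, the same change as from compound 1 to compound 2, at the same place. Among the compounds with values here, with only one measured example of this change, the expectation for compound 4 rests on a 5.6-fold higher number from compound 1 to compound 2 (0.75 log units; beyond the scatter) being repeated on the core of compound 3, so a step of a 5.6-fold higher number from compound 3 to compound 4 (0.75 log units; beyond the scatter) is estimated. Compound 4 is therefore expected to give 13000 nM, with a range of 4000 nM to 45000 nM.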

Compound 4, half-maximal inhibitory concentration: 22600 nM
For compound 4 the middle estimate is 1.7-fold (0.24 log units) below the measured one; low and high end bracket the measured number.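

In this assay the swap to 2-chloro-6-methylphenyl repeats on the pyridin-4-yl core, giving a 9.7-fold higher number from compound 3 to compound 4 (0.99 log units; beyond the scatter), and the two steps agree: the same change on two cores in this assay, a 5.6-fold higher number (0.75 log units; beyond the scatter) from compound 1 to compound 2 and a 9.7-fold higher number (0.99 log units; beyond the scatter) from compound 3 to compound 4, 1.7-fold (0.24 log units) apart, within the scatter of two such steps. The change to pyridin-4-yl also repeats with the other amide aryl group, giving a 2.4-fold lower number from compound 2 to compound 4 (0.38 log units; beyond the scatter), and these two steps agree as well: the same change on two cores in this assay, a 4.1-fold lower number (0.61 log units; beyond the scatter) from compound 1 to compound 3 and a 2.4-fold lower number (0.38 log units; beyond the scatter) from compound 2 to compound 4, 1.7-fold (0.24 log units) apart, within the scatter of two such steps. Each change therefore carries across this one square of compounds, but a single pair per change does not show that it would carry to other cores or other amide aryl groups.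

The compounds shown leave open how a nitrile or a methoxy group on the amide aryl ring would behave. They also leave open how pyridin-3-yl would compare with pyridin-4-yl.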